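Anilide series on a shared boron-containing core

The source may report more compounds than this note shows. Statements on the series, on what has been measured and on what is new or still open speak of the compounds shown alone.

Three anilides on the shared core have been measured in a functional assay on HCT-116 cells (Homo sapiens) for antiproliferative activity, read by MTT assay, with a stated time of 72 h; a lower number here means a stronger inhibitor, a higher number a weaker inhibitor. Compound 1 `CC(C)c1cccc(NC(=O)CCc2cccc3c2B(O)OC3)c1` gives 1600 nM there, which is the second highest of the three numbers. Compound 2 `COc1ccccc1NC(=O)CCc1cccc2c1B(O)OC2` gives 430 nM in this assay, a lower number than compound 1 by a margin beyond the scatter. Compound 3 `Cc1cc(C)c(NC(=O)CCc2cccc3c2B(O)OC3)c(C)c1` gives 64000 nM in this assay, the highest number of the set, well beyond the scatter from compound 1. Among the measured compounds shown here, the three differ from one another in more than one place, so no single step between them is defined.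

Compound 4 `N#Cc1cccc(-c2cccc(NC(=O)CCc3cccc4c3B(O)OC4)c2)c1` is the next entry and is not yet measured in this assay. It differs from compound 1 in one place: 3-cyanophenyl in place of isopropyl on an aromatic carbon. For the measured compounds named here, nothing among the measured compounds carries an aryl substituent on the anilide ring, so the data give no direct precedent for this change. The working expectation is a step of a 1.6-fold lower number from compound 1 to compound 4 (0.20 log units; within the scatter), modest and without a firm direction. For compound 4 the estimate in this assay is 1000 nM, with a range of 200 nM to 5000 nM.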

Compound 4, half-maximal inhibitory concentration: 140 nM
Compound 4: middle estimate off by 7.1-fold (0.85 log units), on the high side; measured number outside the range, below it.
By their numbers in this assay, from the lowest: compound 4; then compound 2; then compound 1; then compound 3.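

Among the compounds shown here, putting 3-cyanophenyl in place of isopropyl on this aromatic carbon gives an 11-fold lower number from compound 1 to compound 4 (1.06 log units; beyond the scatter) in this assay and is the first read on an aryl substituent at the anilide ring. The position therefore accepts a group of 8 heavy atoms, with a six-membered aromatic ring and a nitrile, in place of one of 3 heavy atoms, and the number falls rather than rises. No measurement at hand bears on the reason for this step.

Going by these compounds, whether the added aromatic ring or the nitrile carries the step stays open, and an unsubstituted phenyl at this position would separate the two. Also open, on these data alone, is how much further growth the position accepts, for instance a morpholine or a primary amine on the outer ring.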